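This account rests on a few compounds, and the source may have more. Where it says the series, first, only, none or still open, it means among the compounds named here.

In a functional assay on MCF7 cells (Homo sapiens) for inhibition, read by sulforhodamine B assay, with a stated time of 72 h (a higher number here means a weaker inhibitor of growth, a lower number a stronger inhibitor of growth), compound 1 `CNC(=O)/C=C/c1ccncc1-c1ccc2cc[nH]c2c1` gives 9230 nM, so it does little to slow the growth of these cells. From the compounds shown here alone, compound 2 `O=C(/C=C/c1ccncc1-c1ccc2cc[nH]c2c1)N1CCOCC1` gives > 10000 nM, which is a limit of the assay and not a number, so its true position on the scale is unknown. Compound 3 `O=C(O)/C=C/c1ccncc1-c1ccc2cc[nH]c2c1` carries hydroxy in place of morpholin-4-yl on a carbonyl carbon, so that (morpholin-4-yl)carbonyl becomes carboxy (hydroxy in place of morpholin-4-yl on a carbonyl carbon). Among the compounds with values here, only one measured step changes a group on this carbonyl carbon: an at least 1.0-fold higher number from compound 1 to compound 2 (0.03 log units; that floor lies within the scatter). It ends at a limit, so it bears only loosely on the new change, but it gives no reason to expect a step beyond the scatter in this assay. The expected step is a number no higher from compound 2 to compound 3 (the limit leaves the size open), and another limit reading would be no surprise. For compound 3 the estimate is 10000 nM, with an expected range of 5000 nM to 20000 nM.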

Compound 3, concentration for 50% growth inhibition: > 10000 nM
Compound 3 gave a limit, no number; the forecaster's own chance of this, stated with the estimate: 65%; the middle value sits exactly at the limit.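

Compound 3 gives only a limit of the assay in this assay, not a number, so carboxy on this carbonyl carbon yields no measurable growth inhibition. Hydroxy in place of methylamino gives an at least 1.0-fold higher number from compound 1 to compound 3 (0.03 log units; that floor lies within the scatter), so this change can only be bounded, while the step from the morpholine amide to the acid cannot be read. With a ring of six heavy atoms and a single hydroxy both ending at the same ceiling, neither group gives a reading of growth inhibition on this core, and the limit now describes most of this small set: the limit of > 10000 nM in this assay, at which 2 of the 3 values shown sit.

From the compounds shown here alone, how far compounds 2 and 3 really lie beyond that limit remains open. So does whether a different group on this carbonyl carbon, such as an amide carrying a longer chain ending in an amine, would give a clearly lower number.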